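The compounds below may be only part of what the source reports. "The series", "measured", "known", "first", "only" and "open" are said of these compounds alone.

Of the compounds shown here, three have been measured in a toxicity assay on HeLa cells (Homo sapiens) for cytotoxicity, read by MTT assay, with a stated time of 24 h; a lower number here means a stronger inhibitor, a higher number a weaker inhibitor. Compound 1 `CCOC(=O)N1CCN(C(=S)SCC(O)Cn2c([N+](=O)[O-])cnc2C)CC1` gives 1610000 nM. Compound 2 `Cc1ncc([N+](=O)[O-])n1CC(O)Cn1nnc2ccccc21` gives 4240000 nM. Compound 3 `CCN1CCN(C(=S)SCC(O)Cn2cc([N+](=O)[O-])nc2C)CC1` gives only a limit of the assay, > 5000000 nM, so its true value is not known; it stands at the limit of > 5000000 nM in this assay, at which 1 of the 3 values shown sits. Within the data shown here, no two of the measured compounds differ in one place alone, so there is no measured step to lean on.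

Compound 4 `Cc1nc([N+](=O)[O-])cn1CC(O)CSC(=S)N1CCN(c2cccc(Cl)c2)CC1` is the next compound. It differs from compound 3 by 3-chlorophenyl in place of ethyl on an amine nitrogen in a ring. Without a measured step of this kind, the size of the change in this assay is open; the expectation is a step no larger than the usual scatter, with no firm direction. On that basis compound 4 is expected to give 4000000 nM, within a range from 1200000 nM to 12000000 nM. The expected step is an at least 1.2-fold lower number from compound 3 to compound 4 (0.09 log units; that floor lies within the scatter).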

Compound 4, half-maximal inhibitory concentration: 1740000 nM
Estimate against measurement, compound 4: 2.3-fold (0.36 log units) above; measured number inside the range.
By their numbers in this assay, from the lowest: compounds 1 and 4 (each within the scatter of the next); then compound 2. At a limit, above all of these: compound 3.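

In this assay, among these compounds, the step gives the first measured reading at this position: 3-chlorophenyl in place of ethyl on an amine nitrogen in a ring brings an at least 2.8-fold lower number from compound 3 to compound 4 (0.45 log units; beyond the scatter) for this pair. The change in this group therefore moves the number beyond the usual scatter, so this site on the ring is not silent in this assay. Compound 3 gives only > 5000000 nM as a limit of the assay, so the true size of the step stays unknown for this reason: the limit of > 5000000 nM in this assay, at which 1 of the 4 values shown sits.

The compounds shown leave open whether the aromatic ring or the chlorine carries the step, and a plain phenyl on the same nitrogen would separate the two. Also open, on these data alone, is whether a smaller or a more flexible group there, such as methyl or benzyl, would move the number at all.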